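Methyl to Methoxy on the Weakest of Three Compounds

This account rests on a few compounds, and the source may have more. Where it says the series, first, only, none or still open, it means among the compounds named here.

Within the data shown here, compound 2 `CCN1CCN(c2cc(C)c3cc(NC(=O)c4ccccc4C)ccc3n2)CC1` is the weakest of the three compounds measured so far. In a functional assay on MCF7 cells (Homo sapiens) for antiproliferative activity, read by MTT assay, with a stated time of 72 h (a lower number here means a stronger inhibitor, a higher number a weaker inhibitor), compound 2 gives 10900 nM. Compound 1 `CNc1cc(C)c2cc(NC(=O)c3ccc(Cl)c(Cl)c3)ccc2n1` gives 2520 nM in this assay, and compound 3 `Cc1cc(NCCN2CCN(C)CC2)nc2ccc(NC(=O)c3ccc(Cl)c(Cl)c3)cc12` gives 1700 nM; the gaps from compound 2 to each of these lie beyond the scatter, so compound 2 stands clearly at the weak end of the set.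

Compound 4 `CCN1CCN(c2cc(C)c3cc(NC(=O)c4ccccc4OC)ccc3n2)CC1` differs from compound 2 in one place: methoxy in place of methyl on an aromatic carbon. The exchange sits on an aromatic carbon of a six-membered aromatic ring of carbon only, ortho to a large group, within the (2-methylphenyl)carbonyl part that becomes (2-methoxyphenyl)carbonyl.

Only one measured step exists among these compounds, a 1.5-fold lower number from compound 1 to compound 3 (0.17 log units; within the scatter), and it alters the saturated chain on the other side of the shared core, far from the ring where methyl becomes methoxy. It was within the scatter and tells nothing about the present exchange. Among the measured compounds shown here, no measured pair shows methoxy replacing methyl. With no guidance either way, the expected step is none beyond the scatter: a 1.1-fold lower number from compound 2 to compound 4 (0.04 log units; within the scatter). Compound 4 is therefore estimated at 10000 nM in this assay, with a range from 3500 nM to 30000 nM.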

Compound 4, half-maximal inhibitory concentration: 13200 nM
For compound 4 the middle estimate is 1.3-fold (0.12 log units) below the measured one, within the range that was stated.
By their numbers in this assay, from the lowest: compounds 3 and 1 (each within the scatter of the next); then compounds 2 and 4 (each within the scatter of the next).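

Among these compounds, the step of a 1.2-fold higher number from compound 2 to compound 4 (0.08 log units; within the scatter) in this assay is the first measured change at this place, on an aromatic carbon ortho to a large group, since the only earlier step altered the other side of the shared core. It shows that going from 2-methylphenyl to 2-methoxyphenyl, which brings in an oxygen and a hydrogen-bond acceptor that methyl lacks, gives two numbers that cannot be told apart in this assay, so this one exchange does not separate the two compounds. No measurement of any property of these two groups is available to account for this result.

The compounds shown leave open whether a different group at this same place, such as a hydroxy group, an amine, a carboxylic acid or the longer ethoxy chain, would give a step beyond the scatter. They also leave open whether methoxy in place of methyl would read the same way on a compound that differs from compound 2 elsewhere on the shared core.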